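The compounds below may be only part of what the source reports. "The series", "measured", "known", "first", "only" and "open" are said of these compounds alone.

Measured in an ADME assay on microsomes from liver (Homo sapiens) for metabolic stability, read by LC-MS, with a stated time of 30 min, tested at 0.1 uM; a lower number here means that less of the compound is left, a higher number that more of the compound is left:
- compound 1 `FC(F)(F)c1cccc(-c2nc3cnc(Nc4ccccn4)cc3[nH]2)c1`: 69%
- compound 2 `COc1cccnc1Nc1cc2[nH]c(-c3cccc(C(F)(F)F)c3)nc2cn1`: 69%
- compound 3 `FC(F)(F)c1cccc(-c2nc3cnc(Nc4cnccn4)cc3[nH]2)c1`: 43%

In this assay, compound 3 is the lowest of the three at 43%. Compound 4 `Fc1ccc(Nc2cc3[nH]c(-c4cccc(C(F)(F)F)c4)nc3cn2)nc1` is the next to be read against it, with 5-fluoropyridin-2-yl in place of pyrazin-2-yl on a nitrogen on an aromatic ring.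

The closest evidence is the step of a number 26 percentage points lower from compound 1 to compound 3 (beyond the scatter), which is the same kind of exchange run the other way, without the fluorine. The step of a number 26 percentage points lower from compound 2 to compound 3 (beyond the scatter) has the same size. Within the data shown here, the step of no change at the digits printed from compound 1 to compound 2 (within the scatter) shows that one added substituent, a methoxy, left the value unmoved, but no fluorinated compound has been measured, so the range stays wide.

A rise of somewhat less than the reverse of the step to compound 3 is expected, and the estimated step is a number 21 percentage points higher from compound 3 to compound 4 (beyond the scatter). For compound 4 the expected value is 64%, with an estimated range of 47% to 80%.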

Compound 4, percent of the compound remaining: 34%
Estimate against measurement, compound 4: 30 percentage points above, and the stated range ends above it.
By their numbers in this assay, from the lowest: compounds 4 and 3 (each within the scatter of the next); then compounds 1 and 2 (each within the scatter of the next).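

In this assay, a single added group on the pyridin-2-yl is no longer neutral: the fluoro in place of hydrogen gives a large step (a number 35 percentage points lower from compound 1 to compound 4 (beyond the scatter)), while the methoxy left the value unmoved (no change at the digits printed from compound 1 to compound 2 (within the scatter)), and the exchange of 3-methoxypyridin-2-yl for 5-fluoropyridin-2-yl gives a step of the same size (a number 35 percentage points lower from compound 2 to compound 4 (beyond the scatter)). A pyridin-2-yl on this nitrogen therefore does not by itself keep the number of compound 1, and 5-fluoropyridin-2-yl cannot be told apart from pyrazin-2-yl here (a number 9 percentage points lower from compound 3 to compound 4 (within the scatter)). Nothing at hand gives a reason for these differences.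

Still open, from the compounds shown here alone, is whether the fall belongs to the fluoro itself or to its place on the ring, which 5-methoxypyridin-2-yl or 3-fluoropyridin-2-yl would separate. A 5-chloropyridin-2-yl or a 5-methylpyridin-2-yl would show whether other groups at that place read with compound 4 or with compound 1.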